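The source may report more compounds than this note shows. Statements on the series, on what has been measured and on what is new or still open speak of the compounds shown alone.

Three compounds share one core and differ only in the groups attached to it. In a functional assay on MCF7 cells (Homo sapiens) for antiproliferative activity, read by MTT assay, with a stated time of 48 h (a higher number here means a weaker inhibitor, a lower number a stronger inhibitor), compound 1 `CS(=O)(=O)c1ccc(Nc2ncc(F)c(Nc3nc4ccccc4s3)n2)cc1` gives 6880 nM. Compound 3 `Cc1cnc(Nc2ccc(S(C)(=O)=O)cc2)nc1Nc1nc2ccccc2s1` gives 6550 nM in this assay, the lowest of the two numbers shown, with compound 1 nearest; the step of a 1.1-fold lower number from compound 1 to compound 3 (0.02 log units; within the scatter) lies within the scatter. Compound 2 `Cc1cnc(Nc2ccc(C(C)C)cc2)nc1Nc1nc2ccccc2s1` reaches only a limit of this assay, > 50000 nM, as recorded by the limit of > 50000 nM in this assay, at which 1 of the 3 values shown sits. From compound 2 to compound 3 the change is methylsulfonyl in place of isopropyl on an aromatic carbon, and the step is an at least 7.6-fold lower number from compound 2 to compound 3 (0.88 log units; beyond the scatter).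

Compound 4 `Cc1cnc(Nc2ccc([N+](=O)[O-])cc2)nc1Nc1nc2ccccc2s1` has not been measured in this assay. It differs from compound 3 by nitro in place of methylsulfonyl on an aromatic carbon. Among the compounds with values here, no measured step exchanges these two groups, so the only guides are that the group on that aromatic carbon mattered once, in the step of an at least 7.6-fold lower number from compound 2 to compound 3 (0.88 log units; beyond the scatter), and that compound 3 and compound 1 sit within the scatter of each other. The step expected is a 1.2-fold higher number from compound 3 to compound 4 (0.09 log units; within the scatter), nothing beyond the scatter. The estimate for compound 4 is 8000 nM, with a range from 2500 nM to 25000 nM.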

Compound 4, half-maximal inhibitory concentration: > 50000 nM
Compound 4 gave a limit, no number; the forecaster's own chance of this, stated with the estimate: 10%; middle value at least 6.2-fold (0.79 log units) away from the limit.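

In this assay, exchanging methylsulfonyl for nitro on this aromatic carbon, para to a large group, is not a neutral swap: the result is an at least 7.6-fold higher number from compound 3 to compound 4 (0.88 log units; beyond the scatter). The two groups carry the same counts of hydrogen-bond donors and acceptors and neither has a net charge, so these counts do not separate them; among the three groups now seen at this position, only methylsulfonyl gives a measured number, in compound 1 and compound 3. Compound 2 and compound 4 are both limits rather than numbers, so the step between them cannot be read: the limit of > 50000 nM in this assay, at which 2 of the 4 values shown sit.

From the compounds shown here alone, how far compound 2 and compound 4 lie beyond that limit remains open. So does whether an amine, a carboxylic acid or a sulfonamide on this carbon would give a measured number, as methylsulfonyl does.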